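The source may report more compounds than this note shows. Statements on the series, on what has been measured and on what is new or still open speak of the compounds shown alone.

In an assay for inhibition of acyl-CoA:cholesterol acyltransferase (Oryctolagus cuniculus), using microsomes (on this read-out higher numbers stand for weaker inhibition and lower numbers for stronger inhibition), two compounds of one shared core have been measured. Compound 1 `CCCCCCCCCCCCC(C)(C)C(=O)Nc1c(C)cc(C)c2c1OC(C)(C)C2` gives 33 nM. Compound 2 `Cc1cc(C)c(NC(=O)C(C)(C)CCCCCCc2ccccc2)c2c1CC(C)(C)O2` gives 81 nM. Among the compounds with values here, the single step between them, phenyl in place of hexyl on a saturated chain carbon, seven bonds along the chain from a carbonyl carbon, reads a 2.5-fold higher number from compound 1 to compound 2 (0.39 log units; beyond the scatter). Within the data shown here, compound 2 therefore stands at the higher of the two numbers, with compound 1 as its only neighbour.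

Compound 3 `Cc1cc(C)c(NC(=O)C(C)(C)CCCOc2ccc(Cl)cc2)c2c1CC(C)(C)O2` is not yet measured. It differs from compound 2 in one place: 4-chlorophenoxy in place of 3-phenylpropyl on a saturated chain carbon, four bonds along the chain from a carbonyl carbon. Among the measured compounds shown here, the only measured step that bears on this is the one from compound 1 to compound 2, which replaced the far end of the same chain and gave a 2.5-fold higher number from compound 1 to compound 2 (0.39 log units; beyond the scatter). For the measured compounds named here, that step points towards a higher number when the chain end is altered away from the long alkyl chain of compound 1, but the present change also shortens the chain and brings in an oxygen and a chlorine, for which no measured step exists. On that basis the step from compound 2 to compound 3 is expected to be a 1.9-fold higher number from compound 2 to compound 3 (0.27 log units; within the scatter), and compound 3 is estimated at 150 nM, within a range of 40 nM to 600 nM.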

Compound 3, half-maximal inhibitory concentration: 260 nM
The estimate for compound 3 lay 1.7-fold (0.24 log units) below the measured number, within the range that was stated.
By their numbers in this assay, from the lowest: compound 1; then compound 2; then compound 3.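

In this assay, the position on a saturated chain carbon, four bonds along the chain from a carbonyl carbon, now shows a second change that raises the number: 4-chlorophenoxy in place of 3-phenylpropyl gives a 3.2-fold higher number from compound 2 to compound 3 (0.51 log units; beyond the scatter). Measured against the nonyl end of the chain, the same group gives a 7.9-fold higher number from compound 1 to compound 3 (0.90 log units; beyond the scatter), so both chain ends carrying an aromatic ring stand above the plain alkyl chain of compound 1, and weaker inhibition is seen with each. The swap brings in an oxygen and a chlorine together, and nothing on hand gives a reason for the rise.

It remains open which part of the change accounts for the step: the oxygen, the chlorine, or the different chain end as a whole, and a plain phenoxy end would help to separate these. Also open, on these data alone, is how this position would respond to an amine or a carboxylic acid at the end of the chain, or to a longer chain ending in 4-chlorophenoxy.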